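Swapping the ring substituent on a shared core

The source may hold more compounds than are shown below. What is called first, only, known or untested is meant among the compounds shown, and "the series" means these compounds.

Of the compounds shown here, three sharing one core have been measured in a functional assay for antagonist activity at Alpha-1A adrenergic receptor (Oryctolagus cuniculus); a higher number here means weaker binding, a lower number tighter binding. Compound 1, whose structure is `CN(C)C(=O)c1cccnc1NCCCN1CCN(c2ccccc2C#N)CC1`, gives 2 nM. Compound 2, `Cc1ccccc1N1CCN(CCCNc2ncccc2C(=O)N(C)C)CC1`, gives 2 nM, and the step of no change at the digits printed from compound 1 to compound 2 (within the scatter) lies within the scatter. Compound 3, `CSc1ccccc1N1CCN(CCCNc2ncccc2C(=O)N(C)C)CC1`, gives 0.631 nM; it holds the lowest number of the three, and both steps to it, a 3.2-fold lower number from compound 1 to compound 3 (0.50 log units; beyond the scatter) and a 3.2-fold lower number from compound 2 to compound 3 (0.50 log units; beyond the scatter), are modest but beyond the scatter, so compound 3 stands as the tightest binder among the measured compounds.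

Compound 4, `CC(C)c1ccccc1N1CCN(CCCNc2ncccc2C(=O)N(C)C)CC1`, is not yet measured. It differs from compound 3 in one place: isopropyl in place of methylsulfanyl on an aromatic carbon. The two measured steps that bear on this change are those ending at compound 3, since each altered the same aromatic carbon. A methyl there gave the number of compound 2 and a methylsulfanyl the number of compound 3, so an isopropyl, which is neither, is expected to land between these, most likely closer to compound 2. The estimated step of a 2.1-fold higher number from compound 3 to compound 4 (0.31 log units; beyond the scatter) is therefore expected to be a modest rise. For compound 4 the expected value in this assay is 1.3 nM, with a range from 0.5 nM to 3.5 nM.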

Compound 4, dissociation constant: 0.398 nM
The estimate for compound 4 lay 3.3-fold (0.51 log units) above the measured number; the whole stated range lies above it.
By their numbers in this assay, from the lowest: compounds 4 and 3 (each within the scatter of the next); then compounds 1 and 2 (each within the scatter of the next).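

In this assay the step of a 1.6-fold lower number from compound 3 to compound 4 (0.20 log units; within the scatter) shows that this position, an aromatic carbon ortho to a large group, can take isopropyl in place of methylsulfanyl without a change beyond the usual variation. The low number of compound 3 therefore does not depend on the sulfur atom or on the one hydrogen-bond acceptor counted for methylsulfanyl, since isopropyl has neither. The two longer steps, a 5.0-fold lower number from compound 2 to compound 4 (0.70 log units; beyond the scatter) and a 5.0-fold lower number from compound 1 to compound 4 (0.70 log units; beyond the scatter), both go beyond the scatter, so the four compounds now fall into two groups: methylsulfanyl and isopropyl at the low end, methyl and nitrile at the higher end.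

Nothing available here explains why these groups sort in this way. As far as these compounds go, it also remains open whether a cyclopropyl or phenyl group at this carbon would keep the number as low, and whether an amine or a carboxylic acid there would raise it.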